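Hydroxy in place of carbamoyl: working notes

The source may report more compounds than this note shows. Statements on the series, on what has been measured and on what is new or still open speak of the compounds shown alone.

In an ADME assay on HEK293 cells (Homo sapiens) for cytotoxicity, with a stated time of 72 h (a higher number here means that more compound is needed for the effect, a lower number that less compound is needed), compound 3 `Cc1cc(NC(=O)Nc2ccc(C(N)=O)cc2)c2ccccc2n1` reads > 25000 nM, which is a limit and not a number. Compound 2 `Cc1cc(NC(=O)Nc2ccc(N(C)C)cc2)c2ccccc2n1` reads > 25000 nM, also a limit. Among the measured compounds shown here, compound 1 `CCc1ccc(NC(=O)Nc2cc(C)nc3ccccc23)cc1` gives the only true number so far, 16000 nM. The series therefore shows (the limit of > 25000 nM in this assay, at which 2 of the 3 values shown sit).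

Compound 4 `Cc1cc(NC(=O)Nc2ccc(O)cc2)c2ccccc2n1` differs from compound 3 by one change: hydroxy in place of carbamoyl on an aromatic carbon, para to a large group (hydroxy in place of carbamoyl on an aromatic carbon).

For the measured compounds named here, no measured step involves hydroxy, so the available steps bear on this change only indirectly. Carbamoyl in place of ethyl gave an at least 1.5-fold higher number from compound 1 to compound 3 (0.19 log units; that floor lies within the scatter). Dimethylamino in place of ethyl gave an at least 1.5-fold higher number from compound 1 to compound 2 (0.19 log units; that floor lies within the scatter). Carbamoyl in place of dimethylamino gave a step that the two limits leave unreadable from compound 2 to compound 3. Going by the values given here, neither readable floor goes beyond the scatter, so three different groups at this place have produced no step of established size. On that basis, no step beyond the scatter is expected, and no direction is favoured, although a further limit reading is quite likely.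

The estimated change is an at least 1.0-fold lower number from compound 3 to compound 4 (0.01 log units; that floor lies within the scatter). For compound 4 the expected value is 24000 nM, with an estimated range of 10000 nM to 40000 nM.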

Compound 4, half-maximal effective concentration: > 25000 nM
Compound 4 ended at the assay's limit; the forecaster's own chance of this, stated with the estimate: 55%; middle value at least 1.0-fold (0.01 log units) from the limit.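

In this assay, replacing carbamoyl with hydroxy, which has a smaller heavy-atom count but the same hydrogen-bond donor and acceptor counts, still gives no true number, so this change adds a third group at this place, on an aromatic carbon para to a large group, whose reading is a limit. Both ends of the steps from compound 3 to compound 4 and from compound 2 to compound 4 are limits, so neither step can be read. The one readable step is an at least 1.5-fold higher number from compound 1 to compound 4 (0.19 log units; that floor lies within the scatter), which leaves compound 1 as the only true number and shows no established difference between ethyl and hydroxy, while the series gathers at one reading: the limit of > 25000 nM in this assay, at which 3 of the 4 values shown sit.

As far as these compounds go, whether any group at this place gives a step beyond the scatter remains open, as does whether the number for compound 1 reflects ethyl in particular or a wider trend among hydrocarbon groups. A longer chain such as butyl would bear on the second question, and a carboxylic acid or a primary amine in the same place would extend the comparison with hydroxy and carbamoyl.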